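Sulfonamide nitrogen substituents and deacetylase inhibition

The compounds below may be only part of what the source reports. "The series", "measured", "known", "first", "only" and "open" are said of these compounds alone.

Measured so far:
compound 1, `COCCN(Cc1ccc(C(=O)NO)cc1)S(=O)(=O)c1cc(F)c(F)c(F)c1F`: 27.8 nM in an assay on Sf9 cells for inhibition of protein deacetylase HDAC6 (Homo sapiens), read by fluorescence and mobility shift assay; a lower number here means a stronger inhibitor, a higher number a weaker inhibitor
compound 2, `CC(C)N(Cc1ccc(C(=O)NO)cc1)S(=O)(=O)c1cc(F)c(F)c(F)c1F`: 6 nM

Among the compounds with values here, compound 2 holds the lowest of the two numbers in this assay; the single measured step, a 4.6-fold lower number from compound 1 to compound 2 (0.67 log units; beyond the scatter), separates it from the other compound. Compound 3, `O=C(NO)c1ccc(CN(C2CCCC2)S(=O)(=O)c2cc(F)c(F)c(F)c2F)cc1`, carries cyclopentyl in place of isopropyl on a sulfonamide nitrogen, cyclopentyl in place of isopropyl on a sulfonamide nitrogen. Within the data shown here, that one step is the only guide, and it exchanged 2-methoxyethyl for a branched alkyl, whereas the present change stays among alkyl groups; a smaller shift, if any beyond the scatter, is expected. Compound 3 is therefore expected at 4.5 nM, between 1.5 nM and 13 nM, meaning an expected step of a 1.3-fold lower number from compound 2 to compound 3 (0.12 log units; within the scatter).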

Compound 3, half-maximal inhibitory concentration: 49.9 nM
Compound 3: the middle estimate sits 11-fold (1.04 log units) below what was measured; measured number outside the range, above it.
By their numbers in this assay, from the lowest: compound 2; then compounds 1 and 3 (each within the scatter of the next).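

At this sulfonamide nitrogen, alkyl groups are not interchangeable in this assay: cyclopentyl in place of isopropyl gives an 8.3-fold higher number from compound 2 to compound 3 (0.92 log units; beyond the scatter), beyond the scatter. Cyclopentyl in place of 2-methoxyethyl gives a 1.8-fold higher number from compound 1 to compound 3 (0.25 log units; within the scatter), within the scatter, so among these three compounds only the isopropyl of compound 2 stands apart. Nothing available explains either step. Going by these compounds, whether the ring itself or the larger carbon count drives the step remains open. Cyclopropyl, tert-butyl or an n-pentyl chain could separate the two readings.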